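The source may report more compounds than this note shows. Statements on the series, on what has been measured and on what is new or still open speak of the compounds shown alone.

Compound 1 `COc1cc(-n2ncnc2-c2ccc(Cl)cc2)cc(OC)c1OC`: > 10000 nM
Compound 2 `COc1cc(-n2ncnc2-c2cccc(Cl)c2)cc(OC)c1OC`: > 10000 nM

In a functional assay on MCF7 cells (Homo sapiens) for antiproliferative activity, read by MTT assay, with a stated time of 72 h (on this read-out lower numbers stand for stronger inhibition and higher numbers for weaker inhibition), compound 1 gives > 10000 nM, which is a limit. In this assay compound 2 gives > 10000 nM, which is also a limit, so no number fixes where it stands. Compound 3 `COc1cc(-n2ncnc2-c2cccc(F)c2)cc(OC)c1OC` differs from compound 2 by fluoro in place of chloro on an aromatic carbon, meta to a large group. Among the compounds with values here, only one measured step bears on this change, a step that the two limits leave unreadable from compound 1 to compound 2, and it has no readable size. Within the data shown here, the series so far offers only (the limit of > 10000 nM in this assay, at which 2 of the 2 values shown sit). No direction is favoured in this assay, and the expected change is small: a step that the limit leaves unreadable from compound 2 to compound 3 is the estimated step. Compound 3 is estimated at 12000 nM, with an expected range of 4000 nM to 40000 nM. Another reading that is only a limit is the likeliest outcome.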

Compound 3, half-maximal inhibitory concentration: > 10000 nM
Compound 3: no number, only a limit; the forecaster's own chance of this, stated with the estimate: 80%; the middle value lies beyond the limit too.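

In this assay compound 3 gives > 10000 nM, which is a limit. The steps to compound 3 from compound 1 and compound 2 cannot be read. The compounds shown leave open how far each lies from that limit, and whether fluoro in place of chloro changes activity at all.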